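Sulfonamide aryl swap on the pyrazolone series: cytotoxicity notes

The compounds below may be only part of what the source reports. "The series", "measured", "known", "first", "only" and "open" are said of these compounds alone.

The series shares an arylidene-amino pyrazolone carrying a benzenesulfonamide whose nitrogen bears a heteroaryl group. Compound 1 `NC1=NN(c2ccccc2)C(=O)/C1=C/Nc1ccc(S(=O)(=O)Nc2ccccn2)cc1` is the pyridin-2-yl member; in a functional assay on HepG2 cells (Homo sapiens) for cytotoxicity, tested at 5 uM (a lower number here means a weaker effect, a higher number a stronger effect of the compound at the concentration tested), compound 1 gives 39.5%. Compound 2 `Cc1cc(C)nc(NS(=O)(=O)c2ccc(N/C=C3/C(=N)N(c4ccccc4)N=C3N)cc2)n1` gives 47.9% in this assay, a number within the scatter of compound 1, so the two are not distinguished. Compound 3 `N=C1NN=C(N)/C1=C\Nc1ccc(S(=O)(=O)Nc2cnc3ccccc3n2)cc1`, which carries quinoxalin-2-yl on a different core, gives 18.2% in this assay, a number beyond the scatter below compound 1. Compound 1 thus sits with compound 2 above compound 3.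

Compound 4 `NC1=NN(c2ccccc2)C(=O)/C1=C/Nc1ccc(S(=O)(=O)Nc2cnc3ccccc3n2)cc1` has not been measured. Relative to compound 1 it shows (quinoxalin-2-yl in place of pyridin-2-yl on a sulfonamide nitrogen). Going by the values given here, no measured pair isolates this single exchange on the same core; compound 3 merely shows that quinoxalin-2-yl on another core gives a lower number than compound 1.

From the step from compound 1 to compound 4 in this assay a modest downward shift is expected, of a size that may not clear the scatter: a number 7.5 percentage points lower from compound 1 to compound 4 (within the scatter). Compound 4 is estimated at 32%, with a range of 15% to 50%.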

Compound 4, a percentage reported as activity, at one concentration (the size of the read-out at that concentration, not a potency): 40.4%
Beside the measured number, compound 4's estimate is 8.4 percentage points below it; low and high end bracket the measured number.
By their numbers in this assay, from the lowest: compound 3; then compounds 1, 4 and 2 (each within the scatter of the next).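

In this assay, the exchange of pyridin-2-yl for quinoxalin-2-yl on a sulfonamide nitrogen can now be read on a single core, and it gives a number 0.9 percentage points higher from compound 1 to compound 4 (within the scatter). Going by these compounds alone, on the core of compound 1, the added six-membered aromatic ring of carbon only therefore brings no step that can be told from the scatter, a point the earlier compounds could not settle, as no two of them differed in one place. No measurement on hand explains why the two numbers are not distinguished, so no cause is assigned here.

Open, as far as these compounds go, is whether this holds for other groups on the sulfonamide nitrogen, such as thiazol-2-yl, a plain phenyl ring or an acetyl group, as a single pair on one core says nothing about the wider range of substituents. Also open, from the compounds shown here alone, is how to read compound 3, at 18.2%, which still has no partner differing from it in one place, so its number cannot be tied to any single part of its structure.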